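The source may report more compounds than this note shows. Statements on the series, on what has been measured and on what is new or still open speak of the compounds shown alone.

Series notes, an assay on isolated protein for displacement of a labelled ligand from metabotropic glutamate receptor 5 (Homo sapiens), with a stated time of 60 min, tested at 1 uM; on this read-out higher numbers stand for more inhibition at the one concentration tested (going by the name of the read-out) and lower numbers for less inhibition. Compound 1 `Cc1ccc2ncc(S(=O)(=O)c3ccc(F)cc3)c(N3CCC(C)CC3)c2c1` gives 90% and stands highest of the three measured numbers. Compound 2 `Cc1ccc2ncc(S(=O)(=O)c3ccc(Cl)cc3)c(N3CCC(C)CC3)c2c1` gives 79% and compound 3 `Cc1ccc2ncc(S(=O)(=O)c3ccccc3)c(N3CCC(C)CC3)c2c1` gives 67%. The two steps from compound 1 are a number 11 percentage points lower from compound 1 to compound 2 (beyond the scatter) and a number 23 percentage points lower from compound 1 to compound 3 (beyond the scatter), both changes to the halogen on the pendant aryl ring. Among the measured compounds shown here, compound 4 `CC1CCN(c2c(S(=O)(=O)c3ccc(F)cc3)cnc3ccc(Cl)cc23)CC1` differs from compound 1 by chloro in place of methyl on an aromatic carbon, a change on the core rather than on the pendant ring, so none of the measured steps bears on it directly and the data give no precedent for it. Absent such precedent, a step within the scatter is expected, a number 5 percentage points lower from compound 1 to compound 4 (within the scatter). Compound 4 is accordingly estimated at 85%, in the range 65% to 98%, pending the measurement.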

Compound 4, a percentage reported as inhibition, at one concentration (the size of the read-out at that concentration, not a potency): 89%
The estimate for compound 4 lay 4 percentage points below the measured number; low and high end bracket the measured number.
By their numbers in this assay, from the lowest: compound 3; then compounds 2, 4 and 1 (each within the scatter of the next, the first and the last beyond it).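

On the shared core, chloro in place of methyl on this aromatic carbon gives a number 1 percentage points lower from compound 1 to compound 4 (within the scatter) in this assay. Among the compounds shown here, the earlier compounds varied only the pendant aryl ring, where each step lay beyond the scatter; this is the first reading at a core position, and here this one swap leaves the number within the scatter. Nothing measured here explains why the two groups read alike.

Going by these compounds, whether this position also accepts methoxy, an amine or a carboxylic acid remains open. Also open, on these data alone, is whether compounds reading alike at one concentration would still do so in a full potency measurement.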